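Chloropyridine Amides of the Shared Core in HepG2 Cells

A few compounds are considered here, and "the series" means these few. Any claim that something is new, unique, unknown or untested is made for them only; others in the source may bear on it.

Measured compounds:
compound 1 `C/C=C/C(=O)Nc1cccc(-c2nc3ccccc3s2)c1`
compound 2 `O=C(Nc1cccc(-c2nc3ccccc3s2)c1)c1cnccc1Cl`
compound 3 `O=C(Nc1cccc(-c2nc3ccccc3s2)c1)c1ccc(Cl)nc1Cl`

In an ADME assay on HepG2 cells (Homo sapiens) for inhibition, with a stated time of 72 h (on this read-out lower numbers stand for an effect already at smaller amounts and higher numbers for an effect only at larger amounts of compound), compound 1 reaches only the assay limit, > 25000 nM. Compound 2 also stands at the limit, > 25000 nM. Compound 3 likewise gives only the limit, > 25000 nM. So compound 1 is not placed by a number but by a limit, and the steps a step that the two limits leave unreadable from compound 1 to compound 2, a step that the two limits leave unreadable from compound 1 to compound 3 and a step that the two limits leave unreadable from compound 2 to compound 3 cannot be sized because of the limit of > 25000 nM in this assay, at which 3 of the 3 values shown sit.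

Compound 4 `O=C(Nc1cccc(-c2nc3ccccc3s2)c1)c1ccnc(Cl)c1` differs from compound 1 as follows: 2-chloropyridin-4-yl in place of prop-1-en-1-yl on a carbonyl carbon. The two steps that bear on this change, a step that the two limits leave unreadable from compound 1 to compound 2 and a step that the two limits leave unreadable from compound 1 to compound 3, are both unreadable, so no direction can be expected beyond the scatter. Compound 4 is therefore expected to sit at about 40000 nM, with a range from 15000 nM to 120000 nM. The expected step that the limit leaves unreadable from compound 1 to compound 4 is accordingly small and most likely hidden by the limit.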

Compound 4, half-maximal effective concentration: > 25000 nM
Compound 4: a limit, no number; the forecaster's own chance of this, stated with the estimate: 85%; the middle value is on the limit's open side.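

Compound 4 adds no readable step to compound 1, compound 2 or compound 3, because all four stop at a limit: the limit of > 25000 nM in this assay, at which 4 of the 4 values shown sit. The compounds shown leave open how these amides differ in this assay, since none has a number there.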